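This account rests on a few compounds, and the source may have more. Where it says the series, first, only, none or still open, it means among the compounds named here.

Measured compounds:
Compound 1 `CSc1nc(NCCCCCO)c2cccnc2n1` — in an ADME assay on 184B5 cells (Homo sapiens) for cytotoxicity, read by MTT assay, with a stated time of 72 h (on this read-out higher numbers stand for weaker inhibition of growth and lower numbers for stronger inhibition of growth), compound 1 gives > 100000 nM, a limit of the assay and not a number.
Compound 2 `CSc1nc(NCc2ccccc2)c2ccccc2n1` — in this assay compound 2 gives > 100000 nM, again a limit.
Compound 3 `CSc1nc(NCc2ccccc2)c2cccnc2n1` — in this assay compound 3 gives > 100000 nM, also a limit.

All three values sit at the same point, as noted in the limit of > 100000 nM in this assay, at which 3 of the 3 values shown sit. Compound 3 and compound 1 differ by 4-hydroxybutyl in place of phenyl on a saturated chain carbon bound to a nitrogen on an aromatic ring; the step that the two limits leave unreadable from compound 3 to compound 1 is left unreadable by the two limits. Compound 2 and compound 3 differ in their cores, and that difference is not broken down here. Among the compounds with values here, the unmeasured compound 4 `CSc1nc(NCCCCCO)c2ccccc2n1` differs from compound 2 by 4-hydroxybutyl in place of phenyl on a saturated chain carbon bound to a nitrogen on an aromatic ring, the same change as the one from compound 3 to compound 1. With both ends of the earlier step at the limit and compound 2 at the limit as well, the expected step of a number no higher from compound 2 to compound 4 (the limit leaves the size open) is no more readable than the measured one, and compound 4 is expected to return a limit in this assay too. The estimate for compound 4 is 100000 nM, expected to fall between 30000 nM and 300000 nM.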

Compound 4, concentration for total growth inhibition: > 100000 nM
Compound 4: only a limit was reported; the forecaster's own chance of this, stated with the estimate: 85%; the middle value lies on the limit itself.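

Compound 2 and compound 4 both sit at a limit of the assay, so no new step can be read between them: the limit of > 100000 nM in this assay, at which 4 of the 4 values shown sit. The compounds shown leave open what 4-hydroxybutyl in place of phenyl does in this assay.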